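A few compounds are considered here, and "the series" means these few. Any claim that something is new, unique, unknown or untested is made for them only; others in the source may bear on it.

Measured so far in a functional assay on A2780 cells (Homo sapiens) for inhibition, read by MTT assay, with a stated time of 72 h; on this read-out lower numbers stand for stronger inhibition of growth and higher numbers for weaker inhibition of growth:

compound 1, `CC(C)(C)c1ccc(CNCCNS(=O)(=O)c2cc(C(F)(F)F)cc(C(F)(F)F)c2)cc1`, gives 14000 nM
compound 2, `O=S(=O)(NCCNCc1ccc(-c2ccccc2)cc1)c1cc(C(F)(F)F)cc(C(F)(F)F)c1`, gives 2600 nM
compound 3, `COc1ccc(CNCCCNS(=O)(=O)c2cc(C(F)(F)F)cc(C(F)(F)F)c2)cc1OC`, gives 3800 nM

Compound 3 stands second highest of the three numbers. Its gap to compound 2 lies within the scatter, so the two cannot be ordered; compound 1 sits beyond the scatter above it. Within the data shown here, the single step between compounds that differ in one place is a 5.4-fold lower number from compound 1 to compound 2 (0.73 log units; beyond the scatter), a modest move that comes from exchanging the group on the aromatic ring of the benzyl part.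

Compound 4, `O=S(=O)(NCCCNCc1cccc(Cl)c1)c1cc(C(F)(F)F)cc(C(F)(F)F)c1`, differs from compound 3 in one place: 3-chlorophenyl in place of 3,4-dimethoxyphenyl on a saturated chain carbon bound to an amine nitrogen. Among the measured compounds shown here, the measured data hold nothing on chlorine against methoxy groups on this ring, and the one known step concerns a different exchange, so it bears on the present change only as a sign that this ring tolerates substituent changes without large movement. The expected step is therefore small, a 1.3-fold lower number from compound 3 to compound 4 (0.10 log units; within the scatter), within or close to the scatter. Compound 4 is expected to give 3000 nM in this assay, with a range from 1200 nM to 7500 nM.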

Compound 4, concentration for 50% growth inhibition: 2200 nM
For compound 4 the middle estimate is 1.4-fold (0.13 log units) above the measured one, within the range that was stated.
By their numbers in this assay, from the lowest: compounds 4, 2 and 3 (each within the scatter of the next); then compound 1.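

In this assay the exchange of 3,4-dimethoxyphenyl for 3-chlorophenyl on a saturated chain carbon bound to an amine nitrogen gives a 1.7-fold lower number from compound 3 to compound 4 (0.24 log units; within the scatter), so compound 3 and compound 4 cannot be ordered. Among these compounds, this is the first direct reading of this change: with the chain and the sulfonamide part held constant, the group goes from 10 heavy atoms and 2 hydrogen-bond acceptors to 7 heavy atoms and none, with no step beyond the scatter. No measurement in hand gives a reason for this outcome.

The compounds shown leave open how this ring would read with no substituent at all, or with a nitrile, an amine or a carboxylic acid in place of the chlorine. Also open, from the compounds shown here alone, is how a longer chain would read with the 3-chlorobenzyl group held constant.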